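The compounds below may be only part of what the source reports. "The series", "measured", "known", "first", "only" and "open" are said of these compounds alone.

In a functional assay on HT-29 cells (Homo sapiens) for antiproliferative activity, with a stated time of 48 h (on this read-out higher numbers stand for weaker inhibition and lower numbers for stronger inhibition), compound 1 `CC(C)(C)c1ccc(CNC(=O)NCCCCl)cc1` gives 19000 nM, the lowest of the three numbers to hand. Compound 2 `CCCCCc1cccc(NC(=O)NCCCCl)c1` gives 28000 nM, a value within the scatter of compound 1, so the two cannot be ordered. Compound 3 `CCCCC(OC)c1cccc(NC(=O)NCCCCl)c1` gives 56000 nM, beyond the scatter above compound 1. Going by the values given here, the one single-point step measured so far, a 2.0-fold higher number from compound 2 to compound 3 (0.30 log units; within the scatter), concerns a chain carbon bound to the aromatic ring and does not touch the urea side chain. Compound 4 `CCNC(=O)NCc1ccc(C(C)(C)C)cc1` differs from compound 1 by hydrogen in place of chloromethyl on a saturated chain carbon, two bonds along the chain from an amide-type nitrogen. Among the compounds with values here, no measured step bears on this change; the expectation therefore rests on no precedent and carries a broad range. Compound 4 is estimated at 60000 nM (range 15000 nM to 250000 nM), an expected step of a 3.2-fold higher number from compound 1 to compound 4 (0.50 log units; beyond the scatter).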

Compound 4, half-maximal inhibitory concentration: > 100000 nM
Compound 4 gave a limit, no number; the forecaster's own chance of this, stated with the estimate: 30%; at least 1.6-fold (0.22 log units) between middle value and limit.
By their numbers in this assay, from the lowest: compounds 1, 2 and 3 (each within the scatter of the next, the first and the last beyond it). At a limit, above all of these: compound 4.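

Compound 4 gives > 100000 nM, a limit of the assay and not a number. Hydrogen in place of chloromethyl on a saturated chain carbon, two bonds along the chain from an amide-type nitrogen, gives an at least 5.2-fold higher number from compound 1 to compound 4 (0.72 log units; beyond the scatter), the only step shown on this side chain and one beyond the scatter, so 3-chloropropyl to ethyl does not keep the activity of compound 1. The full size of the step cannot be read: the limit of > 100000 nM in this assay, at which 1 of the 4 values shown sits.

From the compounds shown here alone, whether the chlorine or the chain length carries this loss stays open. A plain propyl chain, a 3-bromopropyl chain or a 3-hydroxypropyl chain would separate the two.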